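Propyl in place of chloro on the shared core

The compounds below may be only part of what the source reports. "The series", "measured", "known", "first", "only" and "open" are said of these compounds alone.

Among the measured compounds shown here, compound 1 `O=C(Nc1nn[nH]n1)c1cccc(Cl)n1` stands highest of the two numbers so far. In a functional assay on the whole organism for inhibition, with Rattus norvegicus as the target, at a dose of 10 mg/kg by the oral route (a higher number here means a stronger effect of the compound at the dose given, a lower number a weaker effect), compound 1 gives 13%. Compound 2 `COc1cccnc1C(=O)Nc1nn[nH]n1` in this assay gives 0%, a gap beyond the usual scatter of this kind of measurement. For the measured compounds named here, compound 1 and compound 2 differ in more than one place, so their two values show only that the weaker number belongs to compound 2.

Compound 3 `CCCc1cccc(C(=O)Nc2nn[nH]n2)n1` has not been measured in this assay. It differs from compound 1 by propyl in place of chloro on an aromatic carbon. Going by the values given here, no measured pair shows a chloro leaving and a propyl entering, so the data give no guide for the size of this exchange. The step from compound 1 to compound 3 is expected to be small, in either direction, not beyond the scatter, estimated at a number 2 percentage points higher from compound 1 to compound 3 (within the scatter). Compound 3 is expected to give about 15% in this assay, with an estimated range from 0% to 35%.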

Compound 3, a percentage reported as inhibition, in the whole organism at one dose (the size of the read-out at that dose, not a potency): 38%
For compound 3 the middle estimate is 23 percentage points below the measured one; the whole stated range lies below it.
By their numbers in this assay, from the lowest: compound 2; then compound 1; then compound 3.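

On the shared core, the aromatic carbon next to the ring nitrogen is a place where one exchange moves the read-out: in this assay, propyl in place of chloro gives a number 25 percentage points higher from compound 1 to compound 3 (beyond the scatter). Among the compounds shown here, this is the first pair that differs in one place only, so it shows that a change at this carbon alone can shift the effect at this oral dose, though the read-out is a size of effect at that dose and not a potency. Nothing available explains the step.

The compounds shown leave open whether the number follows chain length, as a methyl, an ethyl or a longer chain such as butyl would test. They also leave open how a branched isopropyl, an amine or a carboxylic acid on this carbon would compare with propyl.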